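The compounds below may be only part of what the source reports. "The series", "measured", "known", "first", "only" and "open" are said of these compounds alone.

Values in a functional assay on cells (leukaemia cell line, Homo sapiens) for inhibition, read by sulforhodamine B assay, with a stated time of 48 h (on this read-out lower numbers stand for higher toxicity in this test and higher numbers for lower toxicity in this test), follow, each one a limit:

- Compound 1 `O=S(=O)(Nc1cccc(Cl)c1)c1ccc(-c2cnc(C3CC3)o2)cc1` gives > 100000 nM as a limit
- Compound 2 `COc1cc(NS(=O)(=O)c2ccc(-c3cnc(C4CC4)o3)cc2)ccc1F` gives > 100000 nM as a limit
- Compound 3 `O=S(=O)(Nc1ccc(I)c(Cl)c1)c1ccc(-c2cnc(C3CC3)o2)cc1` gives > 100000 nM as a limit

Compound 3 reads > 100000 nM and that is a limit, not a number. Compound 4 `Cc1cc(Cl)cc(NS(=O)(=O)c2ccc(-c3cnc(C4CC4)o3)cc2)c1` keeps the shared core but has 3-chloro-5-methylphenyl in place of 3-chloro-4-iodophenyl on the sulfonamide nitrogen (3-chloro-5-methylphenyl in place of 3-chloro-4-iodophenyl on a sulfonamide nitrogen). For the measured compounds named here, three measured steps bear on this change: (a step that the two limits leave unreadable from compound 1 to compound 2) and (a step that the two limits leave unreadable from compound 1 to compound 3) and (a step that the two limits leave unreadable from compound 2 to compound 3). All three alter the group on that same nitrogen, yet none has a size that can be read. Going by the values given here, with the limit of > 100000 nM in this assay, at which 3 of the 3 values shown sit, as the only guide for compound 3, no step beyond the usual scatter is expected and no direction can be given. The estimated change is a number no higher from compound 3 to compound 4 (the limit leaves the size open) for now. Compound 4 is expected near 100000 nM with an estimated range from 30000 nM to 200000 nM and will most likely be reported as a limit again.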

Compound 4, concentration lethal to 50% of the cells: 84900 nM
For compound 4 the middle estimate is 1.2-fold (0.07 log units) above the measured one; the measured number falls inside the stated range.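

In this assay, for the compounds shown here, compound 4 is the first compound here to give a number rather than a limit: compound 4 gives 84900 nM. That number does not yet show a real effect of 3-chloro-5-methylphenyl on a sulfonamide nitrogen, as the steps are only floors and each lies within the usual scatter: an at least 1.1-fold lower number from compound 3 to compound 4 (0.07 log units; that floor lies within the scatter), an at least 1.1-fold lower number from compound 2 to compound 4 (0.07 log units; that floor lies within the scatter) and an at least 1.1-fold lower number from compound 1 to compound 4 (0.07 log units; that floor lies within the scatter). The number also sits close to where the rest of the set remains: the limit of > 100000 nM in this assay, at which 3 of the 4 values shown sit.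

The steps among compound 1, compound 2 and compound 3 cannot be read, so these groups cannot be ranked against one another. Also open, from the compounds shown here alone, is whether an amine or a carboxylic acid in place of 3-chloro-5-methylphenyl on a sulfonamide nitrogen would move the number beyond the usual scatter.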